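The source may hold more compounds than are shown below. What is called first, only, known or untested is meant among the compounds shown, and "the series" means these compounds.

In an ADME assay on L1210/0 cells (Mus musculus) for cytotoxicity, with a stated time of 48 h (a lower number here means a stronger inhibitor, a higher number a weaker inhibitor), compound 1, with the structure `O=c1[nH]c(=O)n([C@H]2C[C@H](O)[C@@H](CO)O2)cc1/C=N/O`, gives 15500 nM. For the measured compounds named here, that is the only plain number in the set; where compound 1 stands is framed by the limit of > 200000 nM in this assay, at which 2 of the 3 values shown sit. Compound 2, with the structure `Nc1nc(Cl)c2ncn(COCCO)c2n1`, reaches only a limit of the assay, > 200000 nM, in this assay. Compound 3, with the structure `CC1(C)[C@@H](CCCO)C[C@H]1n1cnc2c(Cl)nc(N)nc21`, likewise sits at a limit, > 200000 nM, in this assay. Compound 4, with the structure `CC(C)(C)C#Cc1cn([C@H]2C[C@H](O)[C@@H](CO)O2)c(=O)[nH]c1=O`, has not yet been measured in this assay. It differs from compound 1 by a group of 6 heavy atoms (6 carbon; no ring) in place of a group of 3 heavy atoms (1 carbon, 1 nitrogen, 1 oxygen; no ring), on an aromatic carbon. No measured pair among these compounds differs in a single place, so the size of this step cannot be read from the data. The account therefore treats it as open in direction and of modest size, with a slight lean toward a stronger inhibitor. The estimate for compound 4 in this assay is 9000 nM, with a range from 1500 nM to 60000 nM. The expected step, a 1.7-fold lower number from compound 1 to compound 4 (0.24 log units; within the scatter), is thus small and uncertain.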

Compound 4, half-maximal inhibitory concentration: > 200000 nM
Compound 4 ended at the assay's limit; the forecaster's own chance of this, stated with the estimate: 10%; middle value at least 22-fold (1.34 log units) away from the limit.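

At this aromatic carbon, putting 3,3-dimethylbut-1-yn-1-yl in place of the group of 3 heavy atoms is far from neutral in this assay: it brings an at least 12-fold higher number from compound 1 to compound 4 (1.11 log units; beyond the scatter). For the compounds shown here, this is the first step in the set that can be read, and it shows that the measurable effect of compound 1 does not survive this change on the shared core, although the reading for compound 4 is a limit, so the step gives only a minimum size. Compound 1 now stands alone with a plain number: the limit of > 200000 nM in this assay, at which 3 of the 4 values shown sit.

The compounds shown do not separate the triple bond from the bulky branched end of the new group, so a plain ethynyl or a short unbranched alkyl chain at this position remains an open case. They also leave open whether the group that left could give way to a hydroxymethyl or an amine and keep a plain number.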